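Chlorine in Place of Pyrrolidine: From Compound 1 to Compound 4

The source may report more compounds than this note shows. Statements on the series, on what has been measured and on what is new or still open speak of the compounds shown alone.

Of the compounds shown here, three sharing one core have been tested in a functional assay on SW-620 cells (Homo sapiens) for antiproliferative activity, read by MTT assay, with a stated time of 24 h; on this read-out higher numbers stand for weaker inhibition and lower numbers for stronger inhibition. Compound 1 `COc1ccc(C(=O)/C=C/c2ccc(N3CCCC3)cc2)c2c1C=CC(C)(C)O2` gives 7150 nM, the higher of the two plain numbers in this assay. Compound 2 `COc1ccc(C(=O)/C=C/c2ccc3ccccc3n2)c2c1C=CC(C)(C)O2` gives 2250 nM, a gap from compound 1 that lies beyond the usual scatter of repeated measurements. For compound 3 `COc1ccc(C(=O)/C=C/c2cccc3ccccc23)c2c1C=CC(C)(C)O2` this assay reports only a limit, > 10000 nM, which is the limit of > 10000 nM in this assay, at which 1 of the 3 values shown sits.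

Compound 4 `COc1ccc(C(=O)/C=C/c2ccc(Cl)cc2)c2c1C=CC(C)(C)O2` is the next member. Compared with compound 1, the change is chloro in place of pyrrolidin-1-yl on an aromatic carbon. For the measured compounds named here, no measured pair here shows what this change does, so the direction cannot be read from the data.

The step from compound 1 to compound 4 is therefore expected to be small, a 1.4-fold lower number from compound 1 to compound 4 (0.16 log units; within the scatter), roughly at the edge of the usual scatter. For compound 4 the expected value in this assay is 5000 nM, with a range from 1500 nM to 15000 nM, and the chance that only a limit is reported is not negligible.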

Compound 4, half-maximal inhibitory concentration: > 10000 nM
Compound 4: a limit, no number; the forecaster's own chance of this, stated with the estimate: 20%; middle value at least 2.0-fold (0.30 log units) away from the limit.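

In this assay compound 4 gives > 10000 nM, which is a limit and not a number. Chloro in place of pyrrolidin-1-yl on this aromatic carbon provides the first step that can be read at this position, an at least 1.3-fold higher number from compound 1 to compound 4 (0.14 log units; that floor lies within the scatter), and it shows no sign of stronger inhibition with chloro. The true size of the step stays unknown, since only its floor can be stated, and the ceiling of the assay now holds a second compound: the limit of > 10000 nM in this assay, at which 2 of the 4 values shown sit.

With a single step, the compounds shown leave open whether any group on this carbon can give stronger inhibition than pyrrolidin-1-yl does. A dimethylamino group or a piperidine ring in the same place would help show whether an amine here is what goes with a measurable number.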